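Replacing the Cap Group on the Carbonyl Carbon

The source may report more compounds than this note shows. Statements on the series, on what has been measured and on what is new or still open speak of the compounds shown alone.

Within the data shown here, compound 2 `CCC1(OC(=O)N2CCC(Oc3ncnc(Oc4ccc(S(C)(=O)=O)nc4C)c3F)CC2)CC1` has the higher of the two numbers measured so far in a functional assay on isolated protein for inhibition of Glucose-dependent insulinotropic receptor (Rattus norvegicus), read by HTRF and cAMP accumulation; on this read-out higher numbers stand for larger maximal responses and lower numbers for smaller maximal responses: compound 2 gives 83%, while compound 1 `Cc1nc(S(C)(=O)=O)ccc1Oc1ncnc(OC2CCN(C(=O)OC(C)(C)C(F)(F)F)CC2)c1F` gives 79%. Among the measured compounds shown here, the single measured step, a number 4 percentage points higher from compound 1 to compound 2 (within the scatter), exchanged the group on an oxygen next to a carbonyl group, and the two values sit within the usual scatter of each other, so neither compound can be called more or less effective.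

Compound 3 `Cc1nc(S(C)(=O)=O)ccc1Oc1ncnc(OC2CCN(C(=O)SC(C)(C)C)CC2)c1F` remains to be measured. Compared with compound 2, it differs only at the cap on the carbonyl carbon: a group of 5 heavy atoms (4 carbon, 1 sulfur; no ring) in place of a group of 6 heavy atoms (5 carbon, 1 oxygen; one three-membered non-aromatic ring of carbon only), on a carbonyl carbon. That earlier step, which also altered the cap on the same carbonyl, barely moved the read-out. For the measured compounds named here, with no other step on record, compound 3 is expected to stay close to compound 2, with a step of about a number 3 percentage points lower from compound 2 to compound 3 (within the scatter). Compound 3 is therefore estimated at 80%, between 68% and 92%.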

Compound 3, largest response reached (reported as efficacy), in percent of the reference or control that the assay uses: 76%
Estimate against measurement, compound 3: 4 percentage points above; measured number inside the range.
By their numbers in this assay, from the lowest: compounds 3, 1 and 2 (each within the scatter of the next).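

The cap on the carbonyl carbon can now be joined through sulfur as well as through oxygen: in this assay, the change gives a number 7 percentage points lower from compound 2 to compound 3 (within the scatter) and a number 3 percentage points lower from compound 1 to compound 3 (within the scatter). The earlier step changed only the group beyond the oxygen, whereas these two steps also replace the atom attached to the carbonyl carbon, and neither separates the compounds. No measurement available here offers an explanation for these results.

On these data alone, all three caps keep a branched carbon group on that linking atom, so it remains open whether an amine or a plain methyl group on the same carbonyl carbon would stay within the scatter in this assay. The effect of the sulfur alone also remains unresolved, since each step changes the attached carbon group as well.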